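The compounds below may be only part of what the source reports. "The series", "measured", "known", "first", "only" and "open" are said of these compounds alone.

Measured in a functional assay on DU-145 cells (Homo sapiens) for cytotoxicity, read by MTT assay; a lower number here means a stronger inhibitor, a higher number a weaker inhibitor:
- compound 1 `CCCCC(O)CC(=O)O[C@H](CC=C(C)C)C1=CC(=O)c2c(O)ccc(O)c2C1=O`: 45300 nM
- compound 2 `CC[C@](C)(O)CC(=O)O[C@H](CC=C(C)C)C1=CC(=O)c2c(O)ccc(O)c2C1=O`: 20500 nM
- compound 3 `CCCCC(CC(=O)O[C@H](CC=C(C)C)C1=CC(=O)c2c(O)ccc(O)c2C1=O)OC(C)=O`: 67700 nM

Compound 3 stands at the upper end of these numbers. Its nearest neighbour lies within the scatter: a 1.5-fold higher number from compound 1 to compound 3 (0.17 log units; within the scatter). Its furthest neighbour lies beyond it: a 3.3-fold higher number from compound 2 to compound 3 (0.52 log units; beyond the scatter).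

Compound 4 `CCCCCCC(C)(O)CC(=O)O[C@H](CC=C(C)C)C1=CC(=O)c2c(O)ccc(O)c2C1=O` has not yet been measured. It carries 1-hydroxy-1-methylheptyl in place of 1-acetoxypentyl on a saturated chain carbon bound to a carbonyl carbon.

The closest guide is compound 2, which carries 1-hydroxy-1-methylpropyl at that place and gives 20500 nM. The same group accompanies a modest drop from the secondary alcohol: a 2.2-fold lower number from compound 1 to compound 2 (0.34 log units; beyond the scatter). Among the compounds with values here, no measured compound here has the longer chain of compound 4, so this guide is uncertain. A modest step towards a lower number is therefore expected in this assay: a 2.6-fold lower number from compound 3 to compound 4 (0.42 log units; beyond the scatter). The estimate for compound 4 is 26000 nM, with an expected range from 11000 nM to 60000 nM.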

Compound 4, half-maximal inhibitory concentration: > 100000 nM
Compound 4: a limit, no number; the forecaster's own chance of this, stated with the estimate: 5%; middle value at least 3.8-fold (0.58 log units) from the limit.
By their numbers in this assay, from the lowest: compound 2; then compounds 1 and 3 (each within the scatter of the next). At a limit, above all of these: compound 4.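

Keeping the hydroxyl and methyl but lengthening the chain, on a saturated chain carbon bound to a carbonyl carbon, moves the number up, not down: an at least 4.8-fold higher number from compound 2 to compound 4 (0.68 log units; beyond the scatter). The new group also separates from 1-hydroxypentyl, with an at least 2.2-fold higher number from compound 1 to compound 4 (0.34 log units; beyond the scatter), while the comparison with 1-acetoxypentyl gives only a floor, an at least 1.4-fold higher number from compound 3 to compound 4 (0.16 log units; that floor lies within the scatter), and so shows no firm separation. In this assay compound 4 gives > 100000 nM, which is a limit and not a number, so the true size of all these steps stays open: the limit of > 100000 nM in this assay, at which 1 of the 4 values shown sits.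

Only compound 2 and compound 4 carry the hydroxyl and methyl together, so these compounds cannot show whether the number climbs gradually with chain length or jumps at some point. A 1-hydroxy-1-methylpentyl group at this place would fill that gap, and an amine at the end of the longer chain would test whether the chain's length alone matters.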